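Shifting a Hydroxyl on a Shared Core

The compounds below may be only part of what the source reports. "The series", "measured", "known", "first", "only" and "open" are said of these compounds alone.

Compound 3 `Oc1ccc(-c2cc(-c3ccccc3OC(F)(F)F)cc(-c3cccc(O)c3)n2)cc1` is one of three compounds tested in a functional assay on HeLa cells (Homo sapiens) for inhibition; on this read-out lower numbers stand for stronger inhibition and higher numbers for weaker inhibition. Compound 2 `Oc1ccc(-c2cc(-c3ccccc3OC(F)(F)F)cc(-c3ccccc3O)n2)cc1` gives 6010 nM, while compound 3 gives 5800 nM; the step of a 1.0-fold lower number from compound 2 to compound 3 (0.02 log units; within the scatter) shows that exchanging 2-hydroxyphenyl for 3-hydroxyphenyl leaves the read-out essentially unchanged. Compound 1 `Oc1ccc(-c2cc(-c3ccccc3F)cc(-c3ccc(O)cc3)n2)cc1` gives > 50000 nM, which is a limit of the assay and not a number (the limit of > 50000 nM in this assay, at which 1 of the 3 values shown sits). Of the two numbers available, compound 3 holds the lowest, with compound 2 sitting within the scatter of it.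

Compound 4 `Oc1ccc(-c2cc(-c3ccccc3OC(F)(F)F)cc(-c3ccc(O)cc3)n2)cc1` contains the same atoms as compound 3, joined differently: 4-hydroxyphenyl in place of 3-hydroxyphenyl on an aromatic carbon. For the measured compounds named here, the only measured step that bears on this change is the one from compound 2 to compound 3, a hydroxyl shift of the same kind that stayed within the scatter. Compound 1 shares both 4-hydroxyphenyl groups with compound 4 but carries a fluorophenyl group where compound 4 carries a trifluoromethoxyphenyl group, and its value is a limit, so it offers no number to compare. The step of a 1.0-fold higher number from compound 3 to compound 4 (0.01 log units; within the scatter) is therefore expected to stay within the scatter. Compound 4 is estimated at 6000 nM, with a range from 2500 nM to 20000 nM.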

Compound 4, half-maximal inhibitory concentration: 44600 nM
Compound 4: the middle estimate sits 7.4-fold (0.87 log units) below what was measured; the measured number lies above the stated range.
By their numbers in this assay, from the lowest: compounds 3 and 2 (each within the scatter of the next); then compound 4. At a limit, above all of these: compound 1.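

In this assay, moving the hydroxyl around this ring does matter, but only for one of the three arrangements: 4-hydroxyphenyl in place of 3-hydroxyphenyl gives a 7.7-fold higher number from compound 3 to compound 4 (0.89 log units; beyond the scatter), and 4-hydroxyphenyl in place of 2-hydroxyphenyl gives a 7.4-fold higher number from compound 2 to compound 4 (0.87 log units; beyond the scatter), whereas 3-hydroxyphenyl in place of 2-hydroxyphenyl gave a 1.0-fold lower number from compound 2 to compound 3 (0.02 log units; within the scatter). At this place next to the ring nitrogen, 4-hydroxyphenyl therefore parts from the 2-hydroxyphenyl and 3-hydroxyphenyl groups, even though the 3-hydroxyphenyl group it replaces has the same atoms and the same counts of donors and acceptors. Trifluoromethoxy in place of fluoro gives an at least 1.1-fold lower number from compound 1 to compound 4 (0.04 log units; that floor lies within the scatter), but this step starts from a limit of the assay and not a number, so it cannot be read as a size: the limit of > 50000 nM in this assay, at which 1 of the 4 values shown sits.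

The compounds shown do not tell whether the hydroxyl itself matters here, which 4-methoxyphenyl, 4-aminophenyl or plain phenyl at this place could test. They also leave open why the 4-hydroxyphenyl group gives the higher number.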